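Removing the Basic Side Chain from a Triazolopyridine Urea

The source may hold more compounds than are shown below. What is called first, only, known or untested is meant among the compounds shown, and "the series" means these compounds.

Measured compounds:
compound 1 `COc1ncc(-c2ccc3nc(NC(=O)NCCN4CCCC4)nn3c2)cc1NS(=O)(=O)c1ccc(F)cc1` with 960 nM
compound 2 `COc1ncc(-c2ccc3nc(NC(=O)NCCN(C)C)nn3c2)cc1NS(=O)(=O)c1ccc(F)cc1` with 800 nM
compound 3 `COc1ncc(-c2ccc3nc(NC(=O)NCC(=O)N4CCOCC4)nn3c2)cc1NS(=O)(=O)c1ccc(F)cc1` with 2570 nM

In a functional assay on A549 cells (Homo sapiens) for cytotoxicity, read by MTT assay, with a stated time of 72 h (on this read-out lower numbers stand for stronger inhibition and higher numbers for weaker inhibition), compound 1 stands second highest of the three numbers; compound 2 lies within the scatter of it, as a 1.2-fold lower number from compound 1 to compound 2 (0.08 log units; within the scatter) shows, while compound 3 lies beyond it, with a 2.7-fold higher number from compound 1 to compound 3 (0.43 log units; beyond the scatter). Compound 4 `CNC(=O)Nc1nc2ccc(-c3cnc(OC)c(NS(=O)(=O)c4ccc(F)cc4)c3)cn2n1` has not yet been measured. The change from compound 1 to compound 4 is hydrogen in place of (pyrrolidin-1-yl)methyl on a saturated chain carbon bound to an amide-type nitrogen. Among the compounds with values here, no measured step removes this chain outright; the nearest guides are a 2.7-fold higher number from compound 1 to compound 3 (0.43 log units; beyond the scatter) and a 3.2-fold higher number from compound 2 to compound 3 (0.51 log units; beyond the scatter), where the (pyrrolidin-1-yl)methyl or (dimethylamino)methyl gave way to (morpholin-4-yl)carbonyl and the number rose modestly. The author therefore expects a modest rise for compound 4, about a 1.7-fold higher number from compound 1 to compound 4 (0.22 log units; within the scatter). The estimate for compound 4 is 1600 nM, in the range 600 nM to 4500 nM.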

Compound 4, half-maximal inhibitory concentration: 230 nM
The estimate for compound 4 lay 7.0-fold (0.84 log units) above the measured number; the whole stated range lies above it.
By their numbers in this assay, from the lowest: compound 4; then compounds 2 and 1 (each within the scatter of the next); then compound 3.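

With hydrogen on this saturated chain carbon, the number falls whichever group leaves, with a 4.2-fold lower number from compound 1 to compound 4 (0.62 log units; beyond the scatter), a 3.5-fold lower number from compound 2 to compound 4 (0.54 log units; beyond the scatter) and an 11-fold lower number from compound 3 to compound 4 (1.05 log units; beyond the scatter). The earlier compounds shown here compared only substituted chains, so the lower numbers of the two amine-bearing chains, relative to the morpholin-4-yl carbonyl chain, gave no sign that the short methyl of compound 4 would outdo all three in this assay. Nothing available explains this fall.

The compounds shown leave open whether a plain ethyl chain, or a bare amino group in place of methylamino, would lower the number further.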